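This account rests on a few compounds, and the source may have more. Where it says the series, first, only, none or still open, it means among the compounds named here.

Compound 1 `CN(C)c1nc(N)nc2c1ncn2/C=C1/CC1(CO)CO`: > 20000 nM
Compound 2 `Nc1nc(NCc2ccccc2)c2ncn(/C=C3/CC3(CO)CO)c2n1`: 19900 nM
Compound 3 `Nc1nc(N2CCCC2)c2ncn(/C=C3/CC3(CO)CO)c2n1`: > 20000 nM

In an ADME assay on BCBL1 cells (Homo sapiens) for cytotoxicity, with a stated time of 7 days (on this read-out higher numbers stand for lower toxicity in this test and lower numbers for higher toxicity in this test), compound 3 gives only a limit, > 20000 nM. Compound 1 also gives only a limit, > 20000 nM. Together they make up (the limit of > 20000 nM in this assay, at which 2 of the 3 values shown sit). Compound 4 `CSc1nc(N)nc2c1ncn2/C=C1/CC1(CO)CO` carries methylsulfanyl in place of pyrrolidin-1-yl on an aromatic carbon. Three measured steps change the group at this same carbon: a number no higher from compound 1 to compound 2 (the limit leaves the size open), a step that the two limits leave unreadable from compound 1 to compound 3 and a number no lower from compound 2 to compound 3 (the limit leaves the size open). None has a readable size, and none introduces methylsulfanyl. Compound 2 still gives a number, 19900 nM, so a small step at most is expected in this assay, with no firm direction. The expected change is an at least 1.1-fold lower number from compound 3 to compound 4 (0.04 log units; that floor lies within the scatter). For compound 4 the estimate is 18000 nM, with an expected range from 8000 nM to 25000 nM.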

Compound 4, half-maximal cytotoxic concentration: > 20000 nM
Compound 4 gave a limit, no number (the forecaster's own chance of this, stated with the estimate: 65%); middle value at least 1.1-fold (0.04 log units) from the limit.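

In this assay, within the data shown here, methylsulfanyl is the first group at this aromatic carbon without nitrogen, and with no ring, yet compound 4 still gives only a limit. Among these compounds, the one step with a direction is a number no lower from compound 2 to compound 4 (the limit leaves the size open), while the steps linking compound 4 to compound 1 and compound 3 cannot be read. Most of the series now sits at one limit: the limit of > 20000 nM in this assay, at which 3 of the 4 values shown sit.

From the compounds shown here alone, how far the limit compounds differ from one another remains open. So does whether methoxy or a chlorine atom at this carbon would give a number rather than a limit.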